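The source may hold more compounds than are shown below. What is called first, only, known or untested is meant among the compounds shown, and "the series" means these compounds.

Measured so far in a functional assay on PC-3 cells (Homo sapiens) for cytotoxicity, read by sulforhodamine B assay, with a stated time of 48 h; on this read-out lower numbers stand for stronger inhibition and higher numbers for weaker inhibition:
- compound 1, `CC(=O)N1N=C(c2ccco2)CC1c1ccc([N+](=O)[O-])cc1`, gives 21300 nM
- compound 2, `CC(=O)N1N=C(c2cccc3ccccc23)CC1c1ccccc1[N+](=O)[O-]`, gives 3540 nM
- compound 3, `O=CCN1N=C(c2ccc3ccccc3c2)CC1c1ccccc1`, gives 7400 nM

Compound 3 holds the second highest of the three numbers in this assay. Its nearest neighbour is compound 2, whose number is lower by a gap beyond the scatter; compound 1 lies furthest away, with a higher number, again beyond the scatter. No two of these compounds differ in only one place, so no single step between measured compounds can be read off; the three values can only be compared as they stand.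

Compound 4, `COc1ccc(C2CC(c3ccc4ccccc4c3)=NN2CC=O)cc1O`, is not yet measured. It differs from compound 3 by 3-hydroxy-4-methoxyphenyl in place of phenyl on a saturated ring carbon. The change keeps the shared core and the formylmethyl group of compound 3 untouched and alters only the aryl group on the saturated ring carbon. Going by the values given here, no measured pair in this assay isolates such a change, so the direction rests on little. The step of a 1.2-fold lower number from compound 3 to compound 4 (0.09 log units; within the scatter) is expected to be small, with no clear direction beyond the scatter. For compound 4 in this assay the estimate is 6000 nM, with a range from 2500 nM to 15000 nM.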

Compound 4, half-maximal inhibitory concentration: 2040 nM
For compound 4 the middle estimate is 2.9-fold (0.47 log units) above the measured one, and the stated range ends above it.
By their numbers in this assay, from the lowest: compounds 4 and 2 (each within the scatter of the next); then compound 3; then compound 1.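

In this assay, 3-hydroxy-4-methoxyphenyl in place of phenyl on the saturated ring carbon gives a 3.6-fold lower number from compound 3 to compound 4 (0.56 log units; beyond the scatter), the only step shown that isolates a single place, with the shared core and the formylmethyl group unchanged. The earlier compounds shown here, none differing in only one place, could not show that this position responds to a change of aryl group; here the substituted ring is accepted with a lower number, by a gap beyond the scatter, so the aryl group on this carbon is a working point of variation. No measurement at hand accounts for the size or direction of this step.

The hydroxy and methoxy groups enter together, so the share of each remains unresolved; a phenyl carrying only one of them would separate the two. Also open, from the compounds shown here alone, are whether an amine or a carboxylic acid on this aryl ring would move the number the same way, and whether the step would carry over to a compound with acetyl in place of formylmethyl.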